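The compounds below may be only part of what the source reports. "The series", "measured", "known", "first", "only" and "open" are said of these compounds alone.

Working notes on the series around compound 1 `O=C1NCCN1c1ccc(S(=O)(=O)Nc2ccc(F)cc2)cc1`. In a functional assay on HT-29 cells (Homo sapiens) for antiproliferative activity, read by sulforhodamine B assay, with a stated time of 48 h (on this read-out lower numbers stand for stronger inhibition and higher numbers for weaker inhibition), compound 1 gives 370 nM. Within the data shown here, its only measured neighbour is compound 2 `CCCCc1ccc(NS(=O)(=O)c2ccc(N3CCNC3=O)cc2)cc1`, which in this assay gives 610 nM; the step runs a 1.6-fold higher number from compound 1 to compound 2 (0.22 log units; within the scatter), so these two numbers cannot be told apart.

The next compound, compound 3 `Cc1cccc(NS(=O)(=O)c2ccc(N3CCNC3=O)cc2)c1C`, differs from compound 1 at the sulfonamide nitrogen: 2,3-dimethylphenyl in place of 4-fluorophenyl on a sulfonamide nitrogen. Among the measured compounds shown here, the one step that bears on this place is a 1.6-fold higher number from compound 1 to compound 2 (0.22 log units; within the scatter), where a change of the group on the same aromatic ring, butyl in place of fluoro on an aromatic carbon, left the number within the scatter. For the measured compounds named here, with only that single step, and no measured compound carrying a 2,3-dimethylphenyl, the expectation for compound 3 is a step of a 1.4-fold higher number from compound 1 to compound 3 (0.13 log units; within the scatter), that is, no change beyond the scatter. Compound 3 is therefore estimated at 500 nM, with a range from 180 nM to 1500 nM.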

Compound 3, half-maximal inhibitory concentration: 190 nM
Compound 3: the middle estimate sits 2.6-fold (0.42 log units) above what was measured; low and high end bracket the measured number.
By their numbers in this assay, from the lowest: compounds 3, 1 and 2 (each within the scatter of the next, the first and the last beyond it).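

In this assay the step of a 1.9-fold lower number from compound 1 to compound 3 (0.29 log units; within the scatter) stays within the scatter, so at the sulfonamide nitrogen 2,3-dimethylphenyl and 4-fluorophenyl cannot be told apart. Among these compounds, the earlier pair varied only one group on the aromatic ring, whereas here two methyl groups enter and the fluoro leaves; compound 2 gives 610 nM and compound 3 gives 190 nM and these two numbers lie beyond the scatter of each other, so the group at this place can separate numbers. Nothing measured on these groups is at hand to account for the numbers.

On these data alone, what an amine or a carboxylic acid on this aromatic ring would do to the number remains open. Also open, as far as these compounds go, is whether cyclohexyl in place of the phenyl ring would keep the number in the same range.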